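This account rests on a few compounds, and the source may have more. Where it says the series, first, only, none or still open, it means among the compounds named here.

In an assay on HEK293 cells for positive allosteric modulation of metabotropic glutamate receptor 5 (Homo sapiens), read by FLIPR (on this read-out higher numbers stand for an effect only at larger amounts of compound and lower numbers for an effect already at smaller amounts), compound 2 `Cc1cccc(S(=O)(=O)N2CC(c3nc(-c4cccc(Cl)c4)no3)C2)c1` reaches only the limit > 10000 nM, not a number. Compound 1 `Cc1cccc(-c2noc(C3CN(S(=O)(=O)c4cccc(C)c4)C3)n2)c1` likewise sits at the limit > 10000 nM. The step that the two limits leave unreadable from compound 1 to compound 2 therefore stays unreadable, since both ends rest on (the limit of > 10000 nM in this assay, at which 2 of the 3 values shown sit). Compound 3 `Cc1ccc(C(=O)N2CC(c3nc(-c4cccc(F)c4)no3)C2)cc1`, with an amide carbonyl in place of the sulfonyl and fluorine on the distal ring, gives 6800 nM in this assay. Compound 4 `O=S(=O)(c1ccc(Cl)cc1)N1CC(c2nc(-c3cccc(Cl)c3)no2)C1` differs from compound 2 by 4-chlorophenyl in place of 3-methylphenyl on a sulfonyl sulfur. For the measured compounds named here, no measured step touches the ring on the sulfonyl sulfur, so compound 4 is expected to remain at or near the limit, with an estimated value of 15000 nM (range 5000 nM to 40000 nM), meaning an estimated step that the limit leaves unreadable from compound 2 to compound 4.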

Compound 4, half-maximal effective concentration: > 10000 nM
Compound 4: no number, only a limit (the forecaster's own chance of this, stated with the estimate: 65%); the middle value does not contradict the limit.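

In this assay, for the compounds shown here, compound 4 gives only the limit > 10000 nM, not a number, so no step from compound 2 to compound 4 can be read. The compounds shown leave open how 4-chlorophenyl and 3-methylphenyl on a sulfonyl sulfur compare.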